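Benzyloxy halogen swap in the thiourea-benzimidazole series

A few compounds are considered here, and "the series" means these few. Any claim that something is new, unique, unknown or untested is made for them only; others in the source may bear on it.

Measured compounds:
- compound 1 `Cc1ccc(NC(=S)NC(=O)c2ccc(OCc3cccc(Cl)c3)cc2)cc1-c1nc2ccccc2[nH]1`: 35300 nM
- compound 2 `Cc1ccc(NC(=S)NC(=O)c2ccc(OCc3ccccc3Cl)cc2)cc1-c1nc2ccccc2[nH]1`: 23700 nM
- compound 3 `Cc1ccc(NC(=S)NC(=O)c2ccc(OCc3ccc(Cl)c(Cl)c3)cc2)cc1-c1nc2ccccc2[nH]1`: 6270 nM

In a functional assay on HT-29 cells (Homo sapiens) for inhibition, read by MTT assay, with a stated time of 48 h (on this read-out lower numbers stand for stronger inhibition and higher numbers for weaker inhibition), compound 3 gives the lowest of the three numbers: the step of a 5.6-fold lower number from compound 1 to compound 3 (0.75 log units; beyond the scatter) and the step of a 3.8-fold lower number from compound 2 to compound 3 (0.58 log units; beyond the scatter) both lie beyond the scatter, so compound 3 stands apart from compound 1 and compound 2, whose own step a 1.5-fold lower number from compound 1 to compound 2 (0.17 log units; within the scatter) is within the scatter.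

Compound 4 `Cc1ccc(NC(=S)NC(=O)c2ccc(OCc3ccc(F)cc3)cc2)cc1-c1nc2ccccc2[nH]1` differs from compound 3 by 4-fluorophenyl in place of 3,4-dichlorophenyl on a saturated chain carbon bound to an oxygen on an aromatic ring. The measured steps that bear on this are those in which the 3,4-dichlorophenyl group was replaced by a singly chlorinated ring, and both moved the number up by a modest amount on going back from compound 3. A single fluorine is expected to behave more like the single-chlorine cases than like compound 3, so a modest rise in this assay is expected, a 3.5-fold higher number from compound 3 to compound 4 (0.55 log units; beyond the scatter). Compound 4 is therefore estimated at 22000 nM, with a range from 8000 nM to 60000 nM.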

Compound 4, half-maximal inhibitory concentration: 1910 nM
Beside the measured number, compound 4's estimate is 12-fold (1.06 log units) above it; measured number below the stated range.
By their numbers in this assay, from the lowest: compound 4; then compound 3; then compounds 2 and 1 (each within the scatter of the next).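

In this assay, a ring with no chlorine at this position gives the lowest number of the four (a 3.3-fold lower number from compound 3 to compound 4 (0.52 log units; beyond the scatter)), so the 3,4-dichlorobenzyl group is not required for the strongest inhibition in this set. The gaps to the singly chlorinated rings are larger (a 12-fold lower number from compound 2 to compound 4 (1.09 log units; beyond the scatter)) and (an 18-fold lower number from compound 1 to compound 4 (1.27 log units; beyond the scatter)), which shows that the rings carrying one halogen do not behave as a single class: compound 4 lies at the low end of the set, while compound 1 and compound 2 lie at the high end.

On these data alone, it remains open whether the halogen itself or its place on the ring drives these steps, a question that a 4-chlorobenzyl group set against a plain benzyl group would help to separate. Nothing available here accounts for the steps at this position.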